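Thiosemicarbazide series: methyl-to-hydrogen step on the pyridyl ring

A few compounds are considered here, and "the series" means these few. Any claim that something is new, unique, unknown or untested is made for them only; others in the source may bear on it.

Measured in a functional assay on A-375 cells (Homo sapiens) for cytotoxicity, read by MTT assay, with a stated time of 72 h, tested at 1 uM; on this read-out higher numbers stand for more inhibition of growth at the one concentration tested and lower numbers for less inhibition of growth:
compound 1 `Cc1ccnc(/C(N)=N/NC(=S)N2CCN(c3ccccn3)CC2)c1`: 64.4%
compound 2 `Cc1ccnc(/C(N)=N/NC(=S)N2CCSCC2)c1`: 47.7%
compound 3 `N/C(=N\NC(=S)N1CCSCC1)c1ccccn1`: 34%

Compound 1 gives the highest of the three numbers; compound 2 lies below it, and compound 3 lies lowest. The difference between the cores of compound 1 and compound 2 is not broken down here. Between compound 2 and compound 3 the change is hydrogen in place of methyl on an aromatic carbon, and it produced a number 13.7 percentage points lower from compound 2 to compound 3 (beyond the scatter).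

The same kind of change is now to be read for compound 4 `N/C(=N\NC(=S)N1CCN(c2ccccn2)CC1)c1ccccn1`, which differs from compound 1 by hydrogen in place of methyl on an aromatic carbon. Both place lines read alike, so the surroundings of the change match. Starting from the value of compound 1 in this assay, a step of similar size to the one from compound 2 to compound 3 is expected, giving a number 14.4 percentage points lower from compound 1 to compound 4 (beyond the scatter). For compound 4 the estimate in this assay is 50%.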

Compound 4, percent growth inhibition at one concentration: 70%
The estimate for compound 4 lay 20 percentage points below the measured number; the whole stated range lies below it.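

In this assay, the change from 4-methylpyridin-2-yl to pyridin-2-yl gives a number 5.6 percentage points higher from compound 1 to compound 4 (within the scatter), so the drop seen on the core of compound 2 does not recur on the core of compound 1. The effect of this change therefore does not carry over unchanged between these two cores: the same change on two cores in this assay, a number 13.7 percentage points lower (beyond the scatter) from compound 2 to compound 3 and a number 5.6 percentage points higher (within the scatter) from compound 1 to compound 4, 19.3 percentage points apart, beyond the scatter of two such steps
Among these compounds, this rests on only two pairs at a single concentration, and it shows neither why the cores differ nor how the change would behave on any third core.

Still open, from the compounds shown here alone, is how an ethyl group, a methoxy group, a chlorine atom or an amine at the same place on the ring would read on each core. Also open, going by these compounds, is whether such groups would separate the two cores in the same way.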